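The source may report more compounds than this note shows. Statements on the series, on what has been measured and on what is new or still open speak of the compounds shown alone.

Measured so far:
compound 1 `O=S(=O)(c1ccc2cccnc2c1)n1cc(C2=CCNCC2)c2cc(Cl)ccc21` — 9 nM
compound 2 `O=S(=O)(c1cncc2ccccc12)n1cc(C2=CCNCC2)c2cc(Cl)ccc21` — 18 nM

Compound 1 has the lowest of the two numbers in an assay on HEK293 cells for displacement of a labelled ligand from 5-hydroxytryptamine receptor 6 (Homo sapiens), read by scintillation counting; a lower number here means a stronger inhibitor, a higher number a weaker inhibitor; compound 2 sits within the scatter of it, so the two cannot be ranked. Compound 3 `COc1ccc2c(c1)c(C1=CCNCC1)cn2S(=O)(=O)c1ccc2cccnc2c1` has not been measured. It differs from compound 1 in one place: methoxy in place of chloro on an aromatic carbon. Among the compounds with values here, no measured pair shows what this change does; in this assay it is expected to produce no step beyond the scatter, in either direction. Compound 3 is therefore estimated at 10 nM, within 3 nM to 35 nM, an expected step of a 1.1-fold higher number from compound 1 to compound 3 (0.05 log units; within the scatter).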

Compound 3, inhibition constant: 2 nM
Compound 3: middle estimate off by 5.0-fold (0.70 log units), on the high side, outside the stated range (below it).
By their numbers in this assay, from the lowest: compound 3; then compounds 1 and 2 (each within the scatter of the next).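

In this assay, the aromatic carbon carrying the chloro of compound 1 proves sensitive to its substituent: methoxy in place of chloro gives a 4.5-fold lower number from compound 1 to compound 3 (0.65 log units; beyond the scatter) on the same core. The chloro is therefore not needed for strong binding here, and the larger methoxy is accommodated with a gain. Nothing available explains this step. Going by these compounds, whether the same change gives a like step with the sulfonyl group of compound 2 remains open. So does what a hydrogen, a fluoro or a longer ethoxy chain would do at this carbon.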